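The source may hold more compounds than are shown below. What is called first, only, known or untested is meant among the compounds shown, and "the series" means these compounds.

Working notes on the series. Within the data shown here, in a functional assay on NCI-H460 cells (Homo sapiens) for inhibition, read by MTT assay, with a stated time of 24 h, tested at 100 ug/mL (on this read-out lower numbers stand for less inhibition of growth and higher numbers for more inhibition of growth at the one concentration tested), compound 1 (`O=C(CCCCC(S)CCS)Nc1ccccc1`) gives 25.4% and compound 2 (`O=C(CCCCC(S)CCS)Nc1cccc(C(F)(F)F)c1`) gives 32.1%, which places compound 2 within the scatter of compound 1, the only other measured member. The unmeasured compound 3 (`Cc1cccc(NC(=O)CCCCC(S)CCS)c1`) differs from compound 2 at one place: methyl in place of trifluoromethyl on an aromatic carbon. Among the measured compounds shown here, this exchange of methyl in place of trifluoromethyl on an aromatic carbon has no direct measured precedent. For the measured compounds named here, the one measured step that bears on it is a number 6.7 percentage points higher from compound 1 to compound 2 (within the scatter), which concerns trifluoromethyl in place of hydrogen on an aromatic carbon. On that evidence, no change beyond the scatter is expected in this assay, and the data give no firm direction. The expected step is a number 4.1 percentage points lower from compound 2 to compound 3 (within the scatter). The estimate for compound 3 is 28%, with an expected range of 18% to 38%.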

Compound 3, percent growth inhibition at one concentration: 23.1%
For compound 3 the middle estimate is 4.9 percentage points above the measured one; low and high end bracket the measured number.
By their numbers in this assay, from the lowest: compounds 3, 1 and 2 (each within the scatter of the next).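

In this assay the new compound adds methyl as a third group at this place on the aromatic carbon, and neither step leading to it leaves the scatter (a number 9 percentage points lower from compound 2 to compound 3 (within the scatter); a number 2.3 percentage points lower from compound 1 to compound 3 (within the scatter)). Hydrogen, methyl and trifluoromethyl thus cannot be told apart here, and even the exchange of trifluoromethyl, with its 4 heavy atoms, for methyl, with 1 heavy atom, gives no change that can be read as real. No measurement is at hand that could explain this result.

Still open, from the compounds shown here alone, is whether an amine or a carboxylic acid at this place would move the number beyond the scatter. Also open, going by these compounds, is whether a longer chain on the amide carbonyl side of the shared core would do so.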